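Lipoic acid–coumarin conjugates: cytotoxicity on PC-12 cells

The source may hold more compounds than are shown below. What is called first, only, known or untested is meant among the compounds shown, and "the series" means these compounds.

Measured compounds:
- compound 1 `O=C(CCCCC1CCSS1)NCc1cn(CCCOc2ccc3ccc(=O)oc3c2)nn1`, 43.5%
- compound 2 `O=C(CCCCC1CCSS1)NCc1cn(CCCOc2ccc3cc(C(=O)O)c(=O)oc3c2)nn1`, 73.5%

The read-out is a functional assay on PC-12 cells (Rattus norvegicus) for cytotoxicity, read by MTT assay, with stated times of 3 h and 2 h, tested at 50 uM; a lower number here means a weaker effect, a higher number a stronger effect of the compound at the concentration tested. Compound 1 gives 43.5% in this assay, and compound 2 gives 73.5%. Compound 2 stands highest of the two numbers recorded; its nearest neighbour is compound 1, and the step of a number 30 percentage points higher from compound 1 to compound 2 (beyond the scatter) lies beyond the scatter.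

Compound 3 `O=C(CCCCC1CCSS1)NCc1cn(CCCOc2ccc3cc(-c4ccccc4)c(=O)oc3c2)nn1` is not yet measured in this assay. Its change from compound 2 is phenyl in place of carboxy on an aromatic carbon.

Going by the values given here, the only step that bears on this change is a number 30 percentage points higher from compound 1 to compound 2 (beyond the scatter), which shows that the carboxy at this position raises the number relative to hydrogen. Among the compounds with values here, no measured step shows phenyl at this position, so the effect of exchanging carboxy for phenyl is not covered directly; the available numbers only bracket the position between hydrogen and carboxy. With the carboxy removed, the number is expected to fall back toward compound 1, but the phenyl is a new group and its direction is uncertain, so a moderate decrease of about a number 18.5 percentage points lower from compound 2 to compound 3 (beyond the scatter) is expected. Compound 3 is therefore estimated at 55%, with a range from 35% to 78%.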

Compound 3, a percentage reported as activity, at one concentration (the size of the read-out at that concentration, not a potency): 23.1%
The estimate for compound 3 lay 31.9 percentage points above the measured number, and the stated range ends above it.
By their numbers in this assay, from the lowest: compound 3; then compound 1; then compound 2.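

In this assay the carbon of the six-membered aromatic ring with 1 oxygen now proves sensitive in both directions: phenyl in place of hydrogen gives a number 20.4 percentage points lower from compound 1 to compound 3 (beyond the scatter) and so runs opposite to carboxy in place of hydrogen, which gives a number 30 percentage points higher from compound 1 to compound 2 (beyond the scatter). A substituent at this place therefore does not raise the number as such, and the hydrogen of compound 1 falls in the middle of the three. The exchange of carboxy for phenyl gives a number 50.4 percentage points lower from compound 2 to compound 3 (beyond the scatter) and is the largest change seen so far in the series, which makes the identity of the group at this carbon a strong determinant of the read-out at the concentration tested.

The compounds shown leave open whether an amine, a methyl ester or a primary amide at this carbon would stay near the number of compound 2 or that of compound 3, and whether a substituted phenyl would differ from the plain one. Nothing on hand explains why carboxy and phenyl part so widely.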